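Working notes: from propylamino to isopropyl(methyl)amino

The source may report more compounds than this note shows. Statements on the series, on what has been measured and on what is new or still open speak of the compounds shown alone.

In a functional assay on the whole organism with Rattus norvegicus as the target (on this read-out higher numbers stand for an effect only at larger amounts of compound and lower numbers for an effect already at smaller amounts), compound 1 `CCOC(=O)C(=O)Nc1cccc(NC)c1C#N` gives 0.2 mg/kg, and compound 2 `CCCNc1cccc(NC(=O)C(=O)OCC)c1C#N` gives 0.5 mg/kg, the higher of the two numbers. Compound 3 `CCOC(=O)C(=O)Nc1cccc(N(C)C(C)C)c1C#N` carries isopropyl(methyl)amino in place of propylamino on an aromatic carbon. Going by the values given here, one measured step bears on this change: a 2.5-fold higher number from compound 1 to compound 2 (0.40 log units; beyond the scatter), with ethyl in place of hydrogen on a saturated chain carbon bound to the same nitrogen. On that single modest step, another modest move to a higher number is expected in this assay. The expected step is a 2.4-fold higher number from compound 2 to compound 3 (0.38 log units; beyond the scatter). For compound 3 the estimate is 1.2 mg/kg, with an expected range of 0.3 mg/kg to 5 mg/kg.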

Compound 3, dose for half-maximal effect: 0.3 mg/kg
For compound 3 the middle estimate is 4.0-fold (0.60 log units) above the measured one; the measured number falls inside the stated range.
By their numbers in this assay, from the lowest: compounds 1, 3 and 2 (each within the scatter of the next, the first and the last beyond it).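

In this assay, isopropyl(methyl)amino in place of propylamino on this aromatic carbon stays within the scatter (a 1.7-fold lower number from compound 2 to compound 3 (0.22 log units; within the scatter)), and so does isopropyl in place of hydrogen on the nitrogen of the methylamino group of compound 1 (a 1.5-fold higher number from compound 1 to compound 3 (0.18 log units; within the scatter)). This position therefore accepts a group with 0 hydrogen-bond donors, with neither step from compound 3 going beyond the scatter. No measurement at hand gives a reason for these steps.

On these data alone, how a pyrrolidine ring or a butylamino chain on this carbon would compare with compound 3 stays open. So does the effect of the unsubstituted amino group.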